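A Hydroxymethyl Group Added to the Core of Compound 1

This account rests on a few compounds, and the source may have more. Where it says the series, first, only, none or still open, it means among the compounds named here.

Compound 1 `CCCCN(c1nc2ccccc2o1)[C@H](C)c1ccc(-c2ccccc2-c2nnn[nH]2)cc1` was examined in an ADME assay on the whole organism (Macaca fascicularis) for pharmacokinetics, read by LC-MS, using cassette dosing (a higher number here means that a larger share of the oral dose reaches the circulation, a lower number that a smaller share of the oral dose reaches the circulation), where compound 1 gives 1.8%. Among the measured compounds shown here, this is the lowest of the two numbers measured so far. For the measured compounds named here, the only other measured compound, compound 2 `Cc1ccc(-c2nc(=O)o[nH]2)c(-c2ccc([C@@H](C)N(CC3CC3)c3nc4c(C(=O)O)cccc4o3)cc2)c1`, gives 58% in this assay, a value that lies beyond the scatter above compound 1; the two structures differ in several places at once, so the gap cannot be tied to any single change. Compound 3 `CCCCN(c1nc2c(CO)cccc2o1)[C@H](C)c1ccc(-c2ccccc2-c2nnn[nH]2)cc1` has not yet been measured. It differs from compound 1 in one place: hydroxymethyl in place of hydrogen on an aromatic carbon. Going by the values given here, no single-change step has been measured to guide the size of the effect. The step expected here is a number 4.2 percentage points higher from compound 1 to compound 3 (within the scatter), small and upward, mostly within the scatter. Compound 3 is estimated to reach 6%, within a range from 1% to 25%.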

Compound 3, oral bioavailability: 0.8%
Beside the measured number, compound 3's estimate is 5.2 percentage points above it; the measured number lies below the stated range.
By their numbers in this assay, from the lowest: compounds 3 and 1 (each within the scatter of the next); then compound 2.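

Hydroxymethyl in place of hydrogen on this aromatic carbon gives the first single-change step of the series, which reads a number 1 percentage points lower from compound 1 to compound 3 (within the scatter) in this assay and so leaves compound 1 and compound 3 impossible to tell apart. On its own, then, turning 1,3-benzoxazol-2-yl into 4-(hydroxymethyl)-1,3-benzoxazol-2-yl does not account for any large difference in this assay, at least with the rest of compound 1 unchanged. No supporting measurement is available to explain this result.

On these data alone, what remains open is whether an aminomethyl or a methoxymethyl group on the same aromatic carbon would give a step beyond the scatter. As far as these compounds go, it is also open whether hydroxymethyl would give the same small step on another carbon of this ring.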